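Dropping one trifluoromethyl from the amide-linked ring

A few compounds are considered here, and "the series" means these few. Any claim that something is new, unique, unknown or untested is made for them only; others in the source may bear on it.

Compound 1 `COc1cc(Cl)cc(-c2nn(-c3cccc(NC(=O)c4cc(C(F)(F)F)cc(C(F)(F)F)c4)c3)cc2-c2ccncc2)c1`: 46.5%
Compound 2 `COc1cc(Cl)cc(-c2nn(-c3cccc(NC(=O)c4ccc(Cl)c(Cl)c4)c3)cc2-c2ccncc2)c1`: 54.6%

In a functional assay on MDA-MB-468 cells (Homo sapiens) for inhibition, read by sulforhodamine B assay, with a stated time of 48 h, tested at 10 uM (on this read-out higher numbers stand for a weaker effect at the one concentration tested and lower numbers for a stronger effect), compound 1 gives 46.5%, and compound 2 gives 54.6%; the two numbers lie within the usual scatter of each other, so neither stands apart. Compound 3 `COc1cc(Cl)cc(-c2nn(-c3cccc(NC(=O)c4cccc(C(F)(F)F)c4)c3)cc2-c2ccncc2)c1` has not been measured. It differs from compound 1 in one place: hydrogen in place of trifluoromethyl on an aromatic carbon. For the measured compounds named here, with no measured pair showing this kind of step, the expected step is small, toward a weaker effect or none beyond the scatter. Compound 3 is therefore expected to give 55%, between 38% and 72%, an estimated step of a number 8.5 percentage points higher from compound 1 to compound 3 (within the scatter).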

Compound 3, a percentage reported as activity, at one concentration (the size of the read-out at that concentration, not a potency): 47%
Compound 3: the middle estimate sits 8 percentage points above what was measured; the range from low to high includes it.
By their numbers in this assay, from the lowest: compounds 1, 3 and 2 (each within the scatter of the next).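

In this assay, hydrogen in place of trifluoromethyl on this aromatic carbon gives a number 0.5 percentage points higher from compound 1 to compound 3 (within the scatter) and so shows that the second trifluoromethyl is not needed for a read-out that can be told apart from that of compound 1. Likewise, 3-(trifluoromethyl)phenyl in place of 3,4-dichlorophenyl on the carbonyl carbon gives a number 7.6 percentage points lower from compound 2 to compound 3 (within the scatter) and does not separate these two compounds. No evidence here bears on either step.

Open, from the compounds shown here alone, is whether an amine or a carboxylic acid on this aromatic carbon would move the read-out beyond the scatter.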